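An Extra Amino Group on a Core Already at the Limit

This account rests on a few compounds, and the source may have more. Where it says the series, first, only, none or still open, it means among the compounds named here.

Compound 1, `Nc1nccc(Nc2cc(Cl)cc(Cl)c2)n1`, was tested in an assay on cells for inhibition of S-adenosylmethionine decarboxylase proenzyme (Homo sapiens), read by mass spectrometry, at pH 7.2; on this read-out lower numbers stand for stronger inhibition and higher numbers for weaker inhibition. In this assay compound 1 gives > 180000 nM, which is a limit of the assay rather than a measured number. Its relative compound 2, `Nc1cccc(Nc2cc(Cl)cc(Cl)c2)n1`, gives > 180000 nM in this assay, again only a limit. Going by these compounds, both known values sit at the limit of > 180000 nM in this assay, at which 2 of the 2 values shown sit, so compound 1 cannot be placed above or below any other compound, and how far beyond the limit its true potency lies is unknown. The unmeasured compound 3, `Nc1cc(Nc2cc(Cl)cc(Cl)c2)nc(N)n1`, differs from compound 1 by amino in place of hydrogen on an aromatic carbon. For the measured compounds named here, no step between two measured compounds exists to guide the size of this change. With both starting points at the limit, the step expected is a step that the limit leaves unreadable from compound 1 to compound 3, no larger than the scatter. Compound 3 is estimated at 200000 nM, within 30000 nM to 1000000 nM, most likely reported once more only as a limit.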

Compound 3, half-maximal inhibitory concentration: > 180000 nM
Compound 3: a limit, no number; the forecaster's own chance of this, stated with the estimate: 80%; the middle value does not contradict the limit.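

In this assay compound 3 gives > 180000 nM as a limit, not a number. For the compounds shown here, no step from compound 1 to compound 3 can be read, since every value shown is a limit: the limit of > 180000 nM in this assay, at which 3 of the 3 values shown sit. The compounds shown leave open whether amino in place of hydrogen changes inhibition at all, and how far beyond the limit each true potency lies.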